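The source may hold more compounds than are shown below. What is called first, only, known or untested is meant among the compounds shown, and "the series" means these compounds.

Measured so far:
compound 1 `Cc1ccccc1Nc1nc(NC2CCCCC2)ncc1Cl`: > 100000 nM
compound 2 `Cc1ccccc1Nc1nc(Nc2ccc(N3CCN(C(=O)OC(C)(C)C)CC3)cc2)ncc1Cl`: 2250 nM
compound 3 `CN1CCN(c2ccc(Nc3ncc(Cl)c(NCc4ccc(C(F)(F)F)cc4)n3)nc2)CC1`: 28400 nM

Of the compounds shown here, three have so far been tested in a functional assay on MCF7 cells (Homo sapiens) for inhibition, read by CCK-8 assay, with a stated time of 48 h; on this read-out higher numbers stand for weaker inhibition of growth and lower numbers for stronger inhibition of growth. Compound 1 gives > 100000 nM, which is a limit of the assay and not a number, as the limit of > 100000 nM in this assay, at which 1 of the 3 values shown sits, records. Compound 2 gives 2250 nM. Compound 3 gives 28400 nM, the higher of the two actual numbers; compound 2 lies well below it, and that gap is beyond the usual scatter.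

Compound 4 `COc1ccc(Nc2nc(Nc3ccc(N4CCN(C)CC4)cn3)ncc2Cl)cc1` has not yet been measured in this assay. It differs from compound 3 in one place:
4-methoxyphenyl in place of 4-(trifluoromethyl)benzyl on a nitrogen on an aromatic ring
The entering 4-methoxyphenyl resembles the aromatic group that compound 2 bears on its corresponding nitrogen, and compound 2 gives 2250 nM in this assay. On that basis the step of an 8.1-fold lower number from compound 3 to compound 4 (0.91 log units; beyond the scatter) is expected to be a drop beyond the scatter, toward stronger inhibition. Compound 4 is therefore estimated at 3500 nM, with a likely range from 800 nM to 15000 nM.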

Compound 4, concentration for 50% growth inhibition: 8450 nM
Estimate against measurement, compound 4: 2.4-fold (0.38 log units) below; low and high end bracket the measured number.
By their numbers in this assay, from the lowest: compound 2; then compound 4; then compound 3. At a limit, above all of these: compound 1.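

Within the data shown here, with compound 3 and compound 4, the group on a nitrogen on an aromatic ring changes alone for the first time, and the exchange gives a 3.4-fold lower number from compound 3 to compound 4 (0.53 log units; beyond the scatter) in this assay on this pair. The number at this position therefore responds to the group it carries, although the step is modest and a six-membered aromatic ring of carbon only is present on both sides of it. No measurement shown gives a reason for this step.

The exchange alters the link to the ring and the group on the ring together, so the pair cannot separate their shares in the step. Also open, as far as these compounds go, is how the number would move with an amine or a carboxylic acid in place of the methoxy group, or with a longer chain on this nitrogen.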